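The source may report more compounds than this note shows. Statements on the series, on what has been measured and on what is new or still open speak of the compounds shown alone.

Compound 3 `Cc1nn(-c2ncnc3nc[nH]c23)c2c1C(OCc1ccccc1F)CC(=O)N2` gives 4 nM in a functional assay on HEK293 cells for agonist activity at G-protein coupled receptor 39 (Homo sapiens), read by scintillation proximity assay and inositol phosphate accumulation, with a stated time of 75 min, in the presence of a further agent that is not named here; a higher number here means that more compound is needed for the effect, a lower number that less compound is needed. Compound 1 `Cc1nn(-c2ncnc3nc[nH]c23)c2c1C(OCc1ccc(Cl)cc1Cl)CC(=O)N2` gives 4 nM in this assay, and compound 2 `Cc1nn(-c2ncnc3nc[nH]c23)c2c1C(C(=O)NCc1ccc(F)cc1)CC(=O)N2` gives 4 nM in this assay; compound 3 stands level with both, within the scatter. The aryl group on the benzyl chain has been varied once so far, in the step of no change at the digits printed from compound 1 to compound 3 (within the scatter). Compound 4 `Cc1nn(-c2ncnc3nc[nH]c23)c2c1C(OCc1ccccc1C#N)CC(=O)N2` carries cyano in place of fluoro on an aromatic carbon. For the measured compounds named here, only the step from compound 1 to compound 3 bears on this change, and it was flat; on a single flat step the expectation is no step beyond the scatter, in either direction. Compound 4 is therefore expected to give 5 nM, with a range of 2 nM to 15 nM, in this assay. The expected step is a 1.3-fold higher number from compound 3 to compound 4 (0.10 log units; within the scatter), that is, nothing beyond the scatter.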

Compound 4, half-maximal effective concentration: 8 nM
Compound 4: middle estimate off by 1.6-fold (0.20 log units), on the low side; the range from low to high includes it.
By their numbers in this assay, from the lowest: compounds 1, 2, 3 and 4 (each within the scatter of the next).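

In this assay, for the compounds shown here, cyano is accepted on the aromatic carbon ortho to a large group, where the earlier compounds carried only halogens: the result is a 2.0-fold higher number from compound 3 to compound 4 (0.30 log units; within the scatter), and against the 2,4-dichlorophenyl compound it is a 2.0-fold higher number from compound 1 to compound 4 (0.30 log units; within the scatter). A group with a triple bond and a hydrogen-bond acceptor therefore stands at this place with no step beyond the scatter. Nothing available explains this result.

From the compounds shown here alone, what an amine or a carboxylic acid would give on this aromatic carbon remains open. So does the effect of a longer chain between the oxygen and the ring.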